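A few compounds are considered here, and "the series" means these few. Any claim that something is new, unique, unknown or untested is made for them only; others in the source may bear on it.

Going by the values given here, in a functional assay on HCT-116 cells (Homo sapiens) for inhibition, read by MTT assay, with a stated time of 2 days (a higher number here means a weaker inhibitor of growth, a lower number a stronger inhibitor of growth), compound 1 (`Nc1ccccc1NC(=O)CCCNCC(=O)Nc1cccc(Cl)c1`) gives 11600 nM, the higher of the two numbers measured so far. The only other measured relative, compound 2 (`Nc1ccccc1NC(=O)CCCNCC(=O)Nc1ccc(Cl)cc1`), gives 5500 nM. The next structure is compound 3 (`Nc1ccccc1NC(=O)CCCNCC(=O)Nc1ccc(Br)cc1`), which differs from compound 1 in one place: 4-bromophenyl in place of 3-chlorophenyl on an amide-type nitrogen. In words, 4-bromophenyl stands in place of 3-chlorophenyl on an amide-type nitrogen. Among the compounds with values here, the one measured step that bears on this is a 2.1-fold lower number from compound 1 to compound 2 (0.32 log units; beyond the scatter), which is modest but beyond the scatter and places 4-chlorophenyl where 3-chlorophenyl stood. Within the data shown here, no measurement yet shows what 4-bromophenyl does, so a step of similar modest size towards a lower number is expected in this assay, on that single step alone. The estimated value for compound 3 is 5000 nM, with an expected range from 2300 nM to 11000 nM. This estimate means an expected 2.3-fold lower number from compound 1 to compound 3 (0.37 log units; beyond the scatter).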

Compound 3, concentration for 50% growth inhibition: 7700 nM
Beside the measured number, compound 3's estimate is 1.5-fold (0.19 log units) below it; low and high end bracket the measured number.
By their numbers in this assay, from the lowest: compounds 2, 3 and 1 (each within the scatter of the next, the first and the last beyond it).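

On an aromatic carbon, bromo in place of chloro gives a 1.4-fold higher number from compound 2 to compound 3 (0.15 log units; within the scatter), so in this assay the two groups cannot be told apart when each sits on the 4-substituted phenyl. The change from 3-chlorophenyl to 4-bromophenyl gives a 1.5-fold lower number from compound 1 to compound 3 (0.18 log units; within the scatter), which means compound 3 lies within the scatter of both relatives, even though compound 1 and compound 2 lie just beyond the scatter of each other. Nothing available explains these small differences in growth inhibition.

On these data alone, it remains open whether an unsubstituted phenyl or a 4-methoxyphenyl on the same amide-type nitrogen would move the number beyond the scatter of these three compounds. Also open, as far as these compounds go, is what a longer chain in the shared core would do.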